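Chloro in Place of Methoxy: What to Expect for Compound 3

The source may report more compounds than this note shows. Statements on the series, on what has been measured and on what is new or still open speak of the compounds shown alone.

Compound 1 `COc1cc(NC(=O)c2ccc(Cl)c([N+](=O)[O-])c2)ccc1NS(C)(=O)=O` is the reference point. In an ADME assay on RAW264.7 cells (Mus musculus) for cytotoxicity, read by MTT assay, with a stated time of 48 h (a higher number here means a weaker inhibitor, a lower number a stronger inhibitor), compound 1 gives > 250000 nM, which is a limit of the assay rather than a number. That value sits at the limit of > 250000 nM in this assay, at which 1 of the 2 values shown sits. Among the measured compounds shown here, the only other measured compound, compound 2 `CCS(=O)(=O)Nc1ccc(NC(=O)c2ccc(Cl)c([N+](=O)[O-])c2)cc1OC`, gives 5660 nM in this assay. For the measured compounds named here, the single measured step is an at least 44-fold lower number from compound 1 to compound 2 (1.64 log units; beyond the scatter), so compound 1 stands at the weak end of what has been seen so far, with only a limit to its name.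

Compound 3 `CS(=O)(=O)Nc1ccc(NC(=O)c2ccc(Cl)c([N+](=O)[O-])c2)cc1Cl` differs from compound 1 by chloro in place of methoxy on an aromatic carbon. Going by the values given here, the measured step from compound 1 to compound 2 alters the chain on the sulfonyl sulfur, not the aromatic carbon changed here, so it does not bear on this change; no measured step does. With compound 1 at a limit of the assay and no comparison touching the same place, no step beyond the scatter is expected in this assay, in either direction. Compound 3 is therefore estimated at 150000 nM, within 30000 nM to 400000 nM, which means an expected step of an at least 1.6-fold lower number from compound 1 to compound 3 (0.22 log units; that floor lies within the scatter).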

Compound 3, half-maximal inhibitory concentration: 43600 nM
The estimate for compound 3 lay 3.4-fold (0.54 log units) above the measured number; the measured number falls inside the stated range.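

In this assay, the aromatic carbon ortho to the methanesulfonamido group proves to be a place where a single change counts: chloro in place of methoxy there gives an at least 5.7-fold lower number from compound 1 to compound 3 (0.75 log units; beyond the scatter). Among the compounds shown here, until this result, the only measured change was on the chain at the sulfonyl sulfur, whereas compound 3 keeps that methanesulfonamido group and still departs from compound 1 beyond the scatter, which makes this aromatic carbon a second place on the shared core where the number responds. The real size of the step remains unknown, because the value for compound 1 is a limit of the assay and not a number: the limit of > 250000 nM in this assay, at which 1 of the 3 values shown sits.

The compounds shown leave open whether the step reflects the departure of methoxy or the arrival of chloro, as a single replacement at this carbon cannot separate the two, and a hydrogen, a methyl or an amine in the same place would help to tell them apart. On these data alone, it also remains open whether chloro at this carbon gives a similar step when a longer chain, such as ethyl, sits on the sulfonyl sulfur.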